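From 5-fluoropyridin-2-yl to 4-methylphenyl on the shared core

A few compounds are considered here, and "the series" means these few. Any claim that something is new, unique, unknown or untested is made for them only; others in the source may bear on it.

In an ADME assay on a cell-free system (plasma, Rattus norvegicus) for protein binding, compound 1 (`C[C@@H](NC(=O)c1cc(-c2ccc(Cl)cc2)cc(C(C)(C)O)c1)c1ccc(C(F)(F)F)[n+]([O-])c1`) gives 97.4%, while compound 2 (`C[C@@H](NC(=O)c1cc(-c2ccc(F)cn2)cc(C(C)(C)O)c1)c1ccc(C(F)(F)F)[n+]([O-])c1`) gives 55.3%. Among the compounds with values here, compound 2 thus has the higher unbound fraction of the only two values measured so far. The two compounds differ in one place, where 5-fluoropyridin-2-yl stands in place of 4-chlorophenyl, and the step is large: a 17-fold higher unbound fraction from compound 1 to compound 2 (1.24 log units; beyond the scatter).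

Compound 3 (`Cc1ccc(-c2cc(C(=O)N[C@H](C)c3ccc(C(F)(F)F)[n+]([O-])c3)cc(C(C)(C)O)c2)cc1`) changes that same place on the core of compound 2: 4-methylphenyl in place of 5-fluoropyridin-2-yl on an aromatic carbon. The incoming 4-methylphenyl has a ring of carbon only, as the 4-chlorophenyl of compound 1 does. Within the data shown here, the one measured step, a 17-fold higher unbound fraction from compound 1 to compound 2 (1.24 log units; beyond the scatter), is therefore the only guide, and it suggests that most of that gain in free compound could be lost. One step is thin evidence, however, and a 4-methylphenyl group is not a 4-chlorophenyl group, so the return may be incomplete. The expected change is large and towards less free compound: an 8.9-fold lower unbound fraction from compound 2 to compound 3 (0.95 log units; beyond the scatter). For compound 3 the estimated value is 95%, with an expected range from 88% to 98.5%.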

Compound 3, plasma protein binding: 95.4%
Estimate against measurement, compound 3: 1.1-fold (0.04 log units) (unbound fraction) above, and the stated range covers the measured number.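

In this assay, putting 4-methylphenyl at this position gives a 9.7-fold lower unbound fraction from compound 2 to compound 3 (0.99 log units; beyond the scatter), so the free compound gained with 5-fluoropyridin-2-yl does not survive a return to a ring of carbon only. A second carbon-only ring now shows that the result for compound 1 was not tied to its chloro group: methyl in place of chloro gives a 1.8-fold higher unbound fraction from compound 1 to compound 3 (0.25 log units; within the scatter), so the two cannot be told apart here, and among these three compounds only compound 2, the one with a hetero atom in this ring, stands apart. Nothing measured here explains the difference in binding to plasma protein.

As far as these compounds go, the change from compound 2 to compound 3 swaps the ring nitrogen and the fluoro group together, so it remains open which of them goes with the higher unbound fraction; a 4-fluorophenyl group, or a pyridin-2-yl group with no fluorine, would pull the two apart. Also open, from the compounds shown here alone, is how the unbound fraction would respond to an amine or a carboxylic acid on this ring.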